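The source may report more compounds than this note shows. Statements on the series, on what has been measured and on what is new or still open speak of the compounds shown alone.

Measured in a functional assay on PC-3 cells (Homo sapiens) for inhibition, read by sulforhodamine B assay, with a stated time of 48 h, tested at 50 uM (on this read-out lower numbers stand for less inhibition of growth and higher numbers for more inhibition of growth at the one concentration tested), as follows:
- compound 1 (`CCCOc1ccc([C@@H]2CC(=O)c3cc(CC=C(C)C)c(OC)cc3O2)cc1`) gives 54%
- compound 2 (`COc1ccc([C@@H]2C/C(=N/OCc3cn(-c4ccc(C(=O)c5ccccc5)cc4)nn3)c3cc(CC=C(C)C)c(OC)cc3O2)cc1`) gives 40%

Compound 1 stands highest of this pair, and compound 2 lies lower by more than the scatter. Compound 3 (`COc1cc2c(cc1CC=C(C)C)C(=O)C[C@@H](c1ccc(Oc3ccc(F)cc3)cc1)O2`) differs from compound 1 by 4-fluorophenyl in place of propyl on an oxygen on an aromatic ring. Going by the values given here, no measured step covers this change, so no step beyond the scatter is expected in this assay, and the expectation rests only on compound 1 at 54% in that read-out. The estimated a number 2 percentage points higher from compound 1 to compound 3 (within the scatter) is small. For compound 3 the expected value is 56% (range 38% to 74%).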

Compound 3, percent growth inhibition at one concentration: 19%
Compound 3: middle estimate off by 37 percentage points, on the high side; the measured number lies below the stated range.
By their numbers in this assay, from the lowest: compound 3; then compound 2; then compound 1.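

Replacing propyl by 4-fluorophenyl on an oxygen on an aromatic ring gives, in this assay, a number 35 percentage points lower from compound 1 to compound 3 (beyond the scatter). This position is therefore not indifferent to the group it carries: here, an aromatic ring in place of the open chain goes with less inhibition of growth at the one concentration tested. Nothing available explains this drop. The compounds shown leave open whether the drop follows the aromatic ring or the fluorine, and how a plain phenyl, a butyl chain or a chain ending in an amine on that oxygen would read.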